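A few compounds are considered here, and "the series" means these few. Any claim that something is new, unique, unknown or untested is made for them only; others in the source may bear on it.

Measured compounds:
Compound 1, `CCOC(=O)C1=C(C)NC(C)=C(C(=O)OCC)C1c1c(-c2ccc(OC(F)(F)F)cc2)nc2sc(Br)cn12`, gives 1000 nM in an ADME assay on Right cardiac atrium (Cavia porcellus); a higher number here means that more compound is needed for the effect, a lower number that less compound is needed.
Compound 2, `CCOC(=O)C1=C(C)NC(C)=C(C(=O)OCC)C1c1c(-c2ccc([N+](=O)[O-])cc2)nc2sc(Cl)cn12`, gives 2170 nM in this assay.

For the measured compounds named here, compound 2 stands at the higher of the two numbers so far in this assay. Its nearest neighbour is compound 1, whose number lies lower by a gap that is beyond the usual scatter; the two differ in more than one place, so that gap tells nothing about any single change.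

Compound 3, `CCOC(=O)C1=C(C)NC(C)=C(C(=O)OCC)C1c1c(-c2ccc([N+](=O)[O-])cc2)nc2sc(F)cn12`, has not yet been measured in this assay. It differs from compound 2 in one place: fluoro in place of chloro on an aromatic carbon. Going by the values given here, no pair among the measured compounds shows this exchange on its own, and the account therefore rests on compound 2 alone. The step is expected to be small, a 1.1-fold higher number from compound 2 to compound 3 (0.04 log units; within the scatter), with neither direction favoured and most likely nothing beyond the scatter. Compound 3 is thus expected to give about 2400 nM in this assay, estimated to fall between 1000 nM and 6000 nM, pending the measurement.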

Compound 3, half-maximal effective concentration: 77 nM
Estimate against measurement, compound 3: 31-fold (1.49 log units) above; the whole stated range lies above it.
By their numbers in this assay, from the lowest: compound 3; then compound 1; then compound 2.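

In this assay, fluoro in place of chloro on the aromatic carbon next to the ring sulfur gives a 28-fold lower number from compound 2 to compound 3 (1.45 log units; beyond the scatter), so an exchange of one halogen for another at this position is enough to change markedly how much compound is needed for the effect. Compound 1 and compound 2 could not show this: they differ in more than one place, so their gap could not be assigned to the halogen or to any other single change, whereas compound 2 and compound 3 share everything except this one atom. Nothing in the material at hand offers an explanation for the size or direction of this step, so it stands as an observation only.

On these data alone, what remains open is whether the step belongs to fluoro in particular or reflects a wider preference at this position, which a hydrogen, a nitrile or a methoxy group there would help to separate. As far as these compounds go, it is also open whether the same exchange would give a similar step with the trifluoromethoxy group of compound 1 in place of the nitro group shared by compound 2 and compound 3.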